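Swapping Chloro for Nitro on the Benzyl Ring

This account rests on a few compounds, and the source may have more. Where it says the series, first, only, none or still open, it means among the compounds named here.

Compound 1 `COc1cccc(OC)c1OCCNCCOc1ccccc1OCc1ccc(Cl)cc1` is the reference point of this small series. Going by the values given here, in an assay on CHO cells for displacement of a labelled ligand from Alpha-1A adrenergic receptor (Homo sapiens) (on this read-out lower numbers stand for stronger inhibition and higher numbers for weaker inhibition), compound 1 gives 0.251 nM, the lowest number among the three compounds measured so far. Its two neighbours change only the group on the benzyl ring. Compound 2 `COc1cccc(OC)c1OCCNCCOc1ccccc1OCc1ccccc1C` carries a 2-methylphenyl and gives 1.59 nM; compound 3 `COc1cccc(OC)c1OCCNCCOc1ccccc1OCc1ccc(C)cc1` carries a 4-methylphenyl and gives 2 nM. The steps away from compound 1 are both beyond the scatter: a 6.3-fold higher number from compound 1 to compound 2 (0.80 log units; beyond the scatter) and an 8.0-fold higher number from compound 1 to compound 3 (0.90 log units; beyond the scatter). Between the two methyl compounds, a 1.3-fold higher number from compound 2 to compound 3 (0.10 log units; within the scatter), so the two are indistinguishable here.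

Compound 4 `COc1cccc(OC)c1OCCNCCOc1ccccc1OCc1ccc([N+](=O)[O-])cc1` has not yet been measured. Relative to compound 1 the change is nitro in place of chloro on an aromatic carbon of a six-membered aromatic ring of carbon only, para to a large group. Among the compounds with values here, no measured step in this set replaces chloro with nitro, but the step from compound 1 to compound 3 shows that exchanging the chloro at this spot for another group can cost a modest amount. The nitro is expected to behave somewhere between keeping and losing that advantage, so a modest rise in the number is estimated for compound 4: a 4.0-fold higher number from compound 1 to compound 4 (0.60 log units; beyond the scatter). The expected value for compound 4 is 1 nM, within a range from 0.25 nM to 4 nM.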

Compound 4, inhibition constant: 1.26 nM
For compound 4 the middle estimate is 1.3-fold (0.10 log units) below the measured one, and the stated range covers the measured number.
By their numbers in this assay, from the lowest: compound 1; then compounds 4, 2 and 3 (each within the scatter of the next).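

In this assay, nitro is another replacement for the chloro on the benzyl ring that does not hold on to the low number of compound 1: a 5.0-fold higher number from compound 1 to compound 4 (0.70 log units; beyond the scatter). Compound 4 also sits with the two methyl compounds, with a 1.6-fold lower number from compound 3 to compound 4 (0.20 log units; within the scatter) and a 1.3-fold lower number from compound 2 to compound 4 (0.10 log units; within the scatter), so this read-out does not separate it from either of them. Although nitro differs from methyl in its atoms and in its count of hydrogen-bond acceptors, these three compounds cannot be told apart here, and among the four compounds only compound 1, with its chloro, stands apart.

Still open, going by these compounds, is whether another halogen such as fluoro or bromo, or a group such as an amine or a carboxylic acid, placed at this same spot would match compound 1 or fall in with the other three, and whether a chloro elsewhere on the benzyl ring would give the same result. No measured evidence at hand bears on why the chloro stands apart from the other groups.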